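The source may hold more compounds than are shown below. What is called first, only, known or untested is meant among the compounds shown, and "the series" means these compounds.

Measured compounds in a functional assay on A549 cells (Homo sapiens) for antiproliferative activity, read by MTT assay, with a stated time of 72 h; on this read-out higher numbers stand for weaker inhibition and lower numbers for stronger inhibition:
compound 1, `O=C(Nc1ccc(Cl)c(-c2nnc3c(Cl)cccn23)c1)c1ccc(Cl)cc1`: 73600 nM
compound 2, `CS(=O)(=O)c1ccc(C(=O)Nc2ccc(Cl)c(-c3nnc4c(Cl)cccn34)c2)cc1`: > 100000 nM
compound 3, `O=C(Nc1ccc(Cl)c(-c2nnc3c(Cl)cccn23)c1)c1ccc(Cl)cc1Cl`: 61300 nM

The value of compound 2 is a limit of this assay, not a number (the limit of > 100000 nM in this assay, at which 1 of the 3 values shown sits). Among the two numbers, compound 3 holds the lower one, yet its step from compound 1 is a 1.2-fold lower number from compound 1 to compound 3 (0.08 log units; within the scatter), so no order between them can be claimed. Compound 4, `O=C(Nc1ccc(Cl)c(-c2nnc3c(Cl)cccn23)c1)c1ccccc1`, differs from compound 3 in one place: phenyl in place of 2,4-dichlorophenyl on a carbonyl carbon. Going by the values given here, two measured steps touch the same ring: a 1.2-fold lower number from compound 1 to compound 3 (0.08 log units; within the scatter) and an at least 1.6-fold lower number from compound 2 to compound 3 (0.21 log units; that floor lies within the scatter). Both stay within the scatter and run from a related ring to compound 3, which carries the most chlorine. Stripping both chlorines is therefore expected to leave the number at most modestly higher, a step of a 1.5-fold higher number from compound 3 to compound 4 (0.17 log units; within the scatter), so compound 4 is estimated at 90000 nM, ranging from 40000 nM to 200000 nM.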

Compound 4, half-maximal inhibitory concentration: 76900 nM
The estimate for compound 4 lay 1.2-fold (0.07 log units) above the measured number, and the stated range covers the measured number.
By their numbers in this assay, from the lowest: compounds 3, 1 and 4 (each within the scatter of the next). At a limit, above all of these: compound 2.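

Removing both chlorines from the ring on the carbonyl carbon leaves the number in this assay within the scatter (a 1.3-fold higher number from compound 3 to compound 4 (0.10 log units; within the scatter)), and removing only one does the same (a 1.0-fold higher number from compound 1 to compound 4 (0.02 log units; within the scatter)). Among compounds 1, 3 and 4, chlorine on this ring therefore makes no readable difference, and the plain phenyl does as well as either chlorinated ring. Compound 2 gives a limit, not a number, and its step (an at least 1.3-fold lower number from compound 2 to compound 4 (0.11 log units; that floor lies within the scatter)) has only a floor within the scatter: the limit of > 100000 nM in this assay, at which 1 of the 4 values shown sits.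

As far as these compounds go, whether an amine or a carboxylic acid at this place would move the number beyond the scatter stays open.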